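The source may hold more compounds than are shown below. What is called first, only, known or untested is meant among the compounds shown, and "the series" means these compounds.

Three compounds share one core and differ only in the group carried on the sulfonyl sulfur. Compound 1, `CCCS(=O)(=O)Nc1cccc2c1CCCC2c1c[nH]cn1`, carries a propyl; in an assay on isolated protein for binding affinity to Alpha-1D adrenergic receptor (Rattus norvegicus), read by radioligand binding (on this read-out higher numbers stand for weaker inhibition and lower numbers for stronger inhibition), compound 1 gives < 10000 nM, which is a limit of the assay rather than a number. Compound 2, `O=S(=O)(Nc1cccc2c1CCCC2c1c[nH]cn1)C1CC1`, carries a cyclopropyl and in this assay compound 2 gives 2690 nM. Compound 3, `CN(C)S(=O)(=O)Nc1cccc2c1CCCC2c1c[nH]cn1`, carries a dimethylamino and in this assay compound 3 gives 1580 nM. The steps a step that the limit leaves unreadable from compound 1 to compound 2 and a step that the limit leaves unreadable from compound 1 to compound 3 cannot be sized, because the limit of < 10000 nM in this assay, at which 1 of the 3 values shown sits, hides where compound 1 truly lies. Compound 3 stands level with compound 2, since a 1.7-fold lower number from compound 2 to compound 3 (0.23 log units; within the scatter) lies within the scatter; the third value shown is a limit.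

Compound 4, `CC(=O)Nc1cccc2c1CCCC2c1c[nH]cn1`, has not been measured. It differs from compound 3 as acetyl in place of dimethylsulfamoyl on a nitrogen on an aromatic ring, so the whole dimethylsulfamoyl departs and an acetyl takes its place on that nitrogen. Among the compounds with values here, none of the measured steps touches this position in the same way: two of them are unreadable, and the third is within the scatter. No change beyond the scatter is therefore predicted, but the range must stay wide. For compound 4 the expected value is 2500 nM, between 500 nM and 12000 nM, which as a step means an estimated 1.6-fold higher number from compound 3 to compound 4 (0.20 log units; within the scatter).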

Compound 4, inhibition constant: < 10000 nM
Compound 4: no number, only a limit (the forecaster's own chance of this, stated with the estimate: 30%); the middle value does not contradict the limit.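

In this assay compound 4 gives < 10000 nM as a limit of the assay, not a number. Within the data shown here, no step from compound 1, compound 2 or compound 3 to compound 4 can be sized, because of this: the limit of < 10000 nM in this assay, at which 2 of the 4 values shown sit. The compounds shown leave open where compound 1 and compound 4 truly lie, and so whether acetyl in place of dimethylsulfamoyl on that nitrogen changes the reading at all.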